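The source may report more compounds than this note shows. Statements on the series, on what has been measured and on what is new or still open speak of the compounds shown alone.

The measured compounds are: compound 1, `Fc1ccccc1C1=NC(c2ccccc2)CO1`, with 3.51; compound 2, `Fc1cccc(Cl)c1C1=NC(c2ccccc2)CO1`, with 3.45; and compound 3, `Fc1cccc(Cl)c1-c1ncco1`, with 1.89.

In a physicochemical assay for lipophilicity (on this read-out higher numbers stand for higher lipophilicity and lower numbers for lower lipophilicity), compound 1 holds the highest of the three numbers, although compound 2 lies within the scatter of it, and compound 3 lies well below both. The unmeasured compound 4, `Brc1ccccc1C1=NC(c2ccccc2)CO1`, differs from compound 1 by bromo in place of fluoro on an aromatic carbon. Going by the values given here, the one measured step, a number 0.06 log units lower from compound 1 to compound 2 (within the scatter), concerns a chloro added where hydrogen stood, not a halogen exchanged for another, so no step here bears directly on this change. A bromo entering for a fluoro is nonetheless expected to raise the number, so the account estimates a number 0.69 log units higher from compound 1 to compound 4 (beyond the scatter). For compound 4 the expected value is 4.2, in the range 3.8 to 4.6.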

Compound 4, partition coefficient: 3.69
Compound 4: middle estimate off by 0.51 log units, on the high side; measured number below the stated range.
By their numbers in this assay, from the lowest: compound 3; then compounds 2, 1 and 4 (each within the scatter of the next).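

In this assay, going by these compounds alone, bromo in place of fluoro on an aromatic carbon ortho to a large group gives a number 0.18 log units higher from compound 1 to compound 4 (within the scatter), the first reading of one halogen exchanged for another at this position. On the core of compound 1, this exchange of one heavy atom for another, with no hydrogen-bond donors or acceptors and no net charge on either group, therefore stays within the scatter. Nothing measured here gives a reason for this result. On these data alone, whether an amine or a carboxylic acid at this position would move the number beyond the scatter remains open. So does whether bromo in place of fluoro would read the same on the core of compound 3.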